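Pyridin-3-yl in place of pyridin-4-yl: working notes

The source may report more compounds than this note shows. Statements on the series, on what has been measured and on what is new or still open speak of the compounds shown alone.

Measured so far in a functional assay with Rattus norvegicus as the target; on this read-out higher numbers stand for an effect only at larger amounts of compound and lower numbers for an effect already at smaller amounts
- compound 1 `CCCCCCCCC(=O)NCc1ccc(N)c(OC)c1` gives > 10000 nM (a limit)
- compound 2 `CCCCCCCCC(=O)NCc1ccncc1` gives 28000 nM
- compound 3 `CCCCCCCCC(=O)NCc1ccnc(OC)c1` gives 31500 nM

Compound 1 is reported only as a limit (> 10000 nM). Among the compounds with values here, compound 2 (28000 nM) and compound 3 (31500 nM) lie within the scatter of each other, so compound 2 stands level with the only other numeric value.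

The step followed here leads from compound 2 to compound 4 `CCCCCCCCC(=O)NCc1cccnc1`, which carries pyridin-3-yl in place of pyridin-4-yl on a saturated chain carbon bound to an amide-type nitrogen. Within the data shown here, no measured step makes this exchange. The nearest evidence is a 1.1-fold higher number from compound 2 to compound 3 (0.05 log units; within the scatter), where methoxy takes the place of hydrogen on an aromatic carbon. That is a different change and gives only weak guidance, and it favours no direction.

No step beyond the scatter is expected in this assay, and the estimated step is a 1.1-fold lower number from compound 2 to compound 4 (0.03 log units; within the scatter). Compound 4 is estimated at 26000 nM, with an expected range from 11000 nM to 60000 nM.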

Compound 4, half-maximal effective concentration: > 100000 nM
Compound 4 was reported as a limit; the forecaster's own chance of this, stated with the estimate: 20%; middle value at least 3.8-fold (0.58 log units) from the limit.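

In this assay, pyridin-3-yl in place of pyridin-4-yl on a saturated chain carbon bound to an amide-type nitrogen gives an at least 3.5-fold higher number from compound 2 to compound 4 (0.55 log units; beyond the scatter), while methoxy in place of hydrogen on an aromatic carbon gave only a 1.1-fold higher number from compound 2 to compound 3 (0.05 log units; within the scatter). Within the data shown here, this position therefore responds to a change that keeps the same atoms and joins them differently, which the earlier compounds did not show. The reading for compound 4 is a limit and not a number: the limit of > 100000 nM in this assay, at which 1 of the 4 values shown sits.

The compounds shown do not tell what lies behind this step or how far the value of compound 4 lies past its limit. Also open, from the compounds shown here alone, is how pyridin-2-yl at the same place, or a longer chain on the amide carbonyl, would read in this assay.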